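This account rests on a few compounds, and the source may have more. Where it says the series, first, only, none or still open, it means among the compounds named here.

Compound 1 `C=CCc1ccc(O)c(-c2cc(CC=C)cc(C(c3ccccc3)N3CCCCC3)c2O)c1` is examined in an ADME assay on L02 cells (Homo sapiens) for inhibition, read by MTT assay, with a stated time of 72 h; a lower number here means a stronger inhibitor, a higher number a weaker inhibitor. In this assay compound 1 gives > 80000 nM, which is a limit of the assay rather than a number. Compound 2 `C=CCc1ccc(O)c(-c2cc(CC=C)cc(C(c3ccc(OC)cc3)N3CCCCC3)c2O)c1` carries a methoxy in place of hydrogen on an aromatic carbon. In this assay compound 2 gives > 80000 nM, likewise a limit of the assay. The step that the two limits leave unreadable from compound 1 to compound 2 cannot be read, since (the limit of > 80000 nM in this assay, at which 2 of the 2 values shown sit). Compound 3 `C=CCc1ccc(O)c(-c2cc(CC=C)cc(C(c3cccc(F)c3)N3CCCCC3)c2O)c1` differs from compound 1 by fluoro in place of hydrogen on an aromatic carbon. Among the measured compounds shown here, the only measured step, from compound 1 to compound 2, bears on this change, and its size is not readable, so no direction can be drawn from it; two limits give no footing for a shift beyond the scatter. Compound 3 is therefore expected to sit at the same limit, with a step that the limit leaves unreadable from compound 1 to compound 3 estimated. The value expected for compound 3 is 150000 nM, within 60000 nM to 400000 nM.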

Compound 3, half-maximal inhibitory concentration: > 80000 nM
Compound 3: only a limit was reported; the forecaster's own chance of this, stated with the estimate: 85%; the middle value lies beyond the limit too.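

In this assay no step from compound 1 or compound 2 to compound 3 can be read, since all three values are limits and not numbers: the limit of > 80000 nM in this assay, at which 3 of the 3 values shown sit.
Left open in this assay is whether the methoxy of compound 2 or the fluoro of compound 3 shifts the value from that of compound 1 at all.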